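The source may report more compounds than this note shows. Statements on the series, on what has been measured and on what is new or still open speak of the compounds shown alone.

Compound 1 `CN1C/C(=C\c2ccccc2)C(=O)[C@]2(C1)[C@@H](c1ccccc1)CN(C)[C@@]21C(=O)Nc2ccccc21` gives 73.3% in a functional assay on the whole organism (strain Wister albino) for inhibition, with Rattus norvegicus as the target, read by paw edema, with stated times of 1 h and 2 h, at a dose of 50 mg/kg by the intraperitoneal route; a higher number here means more inhibition at the dose given (going by the name of the read-out), a lower number less inhibition.
Compound 2 `CN1C/C(=C\c2ccccc2)C(=O)[C@]2(C1)[C@@H](c1ccccc1)CN(C)[C@@]21C(=O)N(C)c2ccccc21` gives 70.7% in this assay.
Compound 3 `CN1C/C(=C\c2ccc(-c3cccs3)cc2)C(=O)[C@]2(C1)[C@@H](c1ccc(-c3cccs3)cc1)CN(C)[C@@]21C(=O)Nc2ccccc21` gives 70.7% in this assay.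

Compound 2 arises from compound 1 by methyl in place of hydrogen on an amide-type nitrogen in a ring, and that change made a step of a number 2.6 percentage points lower from compound 1 to compound 2 (within the scatter). Compound 3 shares this core only in part; the difference between the two cores is not broken down here, and its value stands level with that of compound 2. Compound 4 `CN1C/C(=C\c2ccc(-c3cccs3)cc2)C(=O)[C@]2(C1)[C@@H](c1ccc(-c3cccs3)cc1)CN(C)[C@@]21C(=O)N(C)c2ccccc21` has not yet been measured; it arises from compound 3 by methyl in place of hydrogen on an amide-type nitrogen in a ring, the same change as before. Because the earlier step was a number 2.6 percentage points lower from compound 1 to compound 2 (within the scatter), compound 4 is expected to lie close to compound 3, with an estimated step of a number 2.7 percentage points lower from compound 3 to compound 4 (within the scatter). In this assay compound 4 is therefore estimated at 68%, expected between 58% and 78%.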

Compound 4, a percentage reported as inhibition, in the whole organism at one dose (the size of the read-out at that dose, not a potency): 68.3%
The estimate for compound 4 lay 0.3 percentage points below the measured number; the measured number falls inside the stated range.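

In this assay methyl in place of hydrogen on an amide-type nitrogen in a ring gave a number 2.4 percentage points lower from compound 3 to compound 4 (within the scatter) on the second core. The change carried over from one core to the other with much the same size: the same change on two cores in this assay, a number 2.6 percentage points lower (within the scatter) from compound 1 to compound 2 and a number 2.4 percentage points lower (within the scatter) from compound 3 to compound 4, 0.2 percentage points apart, within the scatter of two such steps. For the compounds shown here, both steps lie within the scatter, so this shows only that the change made no clear difference on these two cores; it does not show that methyl truly lowers the inhibition, or that other cores would behave alike.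

The compounds shown leave open what an ethyl group, a longer chain or an acetyl group would do on this nitrogen.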